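Chlorophenyl placement on a shared pyridine-type core: notes

The source may hold more compounds than are shown below. What is called first, only, known or untested is meant among the compounds shown, and "the series" means these compounds.

Of the compounds shown here, three have been measured in an assay on isolated protein for inhibition of DNA topoisomerase 1 (Homo sapiens), with a stated time of 30 min, tested at 100 uM; a higher number here means a stronger effect of the compound at the concentration tested, a lower number a weaker effect. Compound 1 `Oc1cccc(-c2cc(-c3cccnc3)nc(-c3ccccc3Cl)c2)c1` gives 0% and compound 2 `Oc1cccc(-c2cc(-c3ccc(Cl)cc3)nc(-c3cccnc3)c2)c1` gives 2.8%; the two lie within the scatter of each other. Compound 3 `Oc1ccc(-c2cc(-c3ccc(Cl)cc3)nc(-c3ccsc3)c2)cc1` gives 47.7%, the highest of the three numbers, beyond the scatter of both others. How the core of compound 3 differs from the core of compound 2 is not broken down here.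

The measured step of a number 2.8 percentage points lower from compound 2 to compound 1 (within the scatter) follows the change (2-chlorophenyl in place of 4-chlorophenyl on an aromatic carbon). The same kind of change leads from compound 3 to the unmeasured compound 4 `Oc1ccc(-c2cc(-c3ccsc3)nc(-c3ccccc3Cl)c2)cc1`, namely (2-chlorophenyl in place of 4-chlorophenyl on an aromatic carbon); around the place the surroundings differ, since in compound 2 the place is meta to a 3-hydroxyphenyl group and meta to a pyridin-3-yl group, whereas in compound 3 it is meta to a 4-hydroxyphenyl group and meta to a thiophen-3-yl group.

For compound 4 a step of about a number 7.7 percentage points lower from compound 3 to compound 4 (within the scatter) in this assay is expected, resting on the small measured step from compound 2 to compound 1; compound 4 is accordingly estimated at 40%, between 18% and 60%.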

Compound 4, a percentage reported as inhibition, at one concentration (the size of the read-out at that concentration, not a potency): 4.1%
Beside the measured number, compound 4's estimate is 35.9 percentage points above it, and the stated range ends above it.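

Replacing 4-chlorophenyl with 2-chlorophenyl gives a number 43.6 percentage points lower from compound 3 to compound 4 (beyond the scatter) in this assay, so the small step seen earlier gives no guide to the size of the step on the core of compound 3. In this series, the size of the step depends on the core, at least for these two cores: the same change on two cores in this assay, a number 2.8 percentage points lower (within the scatter) from compound 2 to compound 1 and a number 43.6 percentage points lower (beyond the scatter) from compound 3 to compound 4, 40.8 percentage points apart, beyond the scatter of two such steps

Which core difference matters is not shown: the core of compound 2 carries 3-hydroxyphenyl and pyridin-3-yl, the core of compound 3 carries 4-hydroxyphenyl and thiophen-3-yl, and these are not separated, while compound 2 at 2.8% leaves little room for any lower number to appear.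

Open, going by these compounds, is whether the large step persists when only 3-hydroxyphenyl replaces 4-hydroxyphenyl, or only pyridin-3-yl replaces thiophen-3-yl, on the core of compound 3. Also open, on these data alone, is what an amine or a carboxylic acid in place of the chlorine would give on that core.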